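A few compounds are considered here, and "the series" means these few. Any claim that something is new, unique, unknown or untested is made for them only; others in the source may bear on it.

Compound 1 `O=C(Nc1cccc(-n2cc(-c3ccncc3)c(-c3ccc(Cl)c(O)c3)n2)c1)Nc1cccc(C(F)(F)F)c1` gives 7900 nM in a functional assay on COLO 205 cells (Homo sapiens) for inhibition, read by sulforhodamine B assay, with a stated time of 48 h (on this read-out lower numbers stand for stronger inhibition of growth and higher numbers for weaker inhibition of growth), the highest of the three numbers to hand. Compound 2 `O=C(Nc1cccc(-n2cc(-c3ccncc3)c(-c3ccc(Cl)c(O)c3)n2)c1)Nc1ccc(Cl)c(Cl)c1` gives 3960 nM; the step of a 2.0-fold lower number from compound 1 to compound 2 (0.30 log units; within the scatter) stays within the scatter. Compound 3 `COc1cc(-c2nn(-c3cccc(NC(=O)Nc4cccc(C(F)(F)F)c4)c3)cc2-c2ccncc2)ccc1Cl` gives 894 nM; the step of an 8.8-fold lower number from compound 1 to compound 3 (0.95 log units; beyond the scatter) lies beyond it. Compound 4 `O=C(Nc1cccc(-n2cc(-c3ccncc3)c(-c3ccc(Cl)c(O)c3)n2)c1)Nc1cc(C(F)(F)F)cc(C(F)(F)F)c1` differs from compound 1 by trifluoromethyl in place of hydrogen on an aromatic carbon. Within the data shown here, only the step between compound 1 and compound 2 concerns the aryl on the amide-type nitrogen, and it stayed within the scatter; no other comparison touches a second trifluoromethyl. In this assay, therefore, no step beyond the scatter is expected from compound 1 to compound 4, a 1.2-fold lower number from compound 1 to compound 4 (0.08 log units; within the scatter). Compound 4 is accordingly estimated at 6500 nM, with a range from 2200 nM to 19000 nM.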

Compound 4, concentration for 50% growth inhibition: 853 nM
Compound 4: middle estimate off by 7.6-fold (0.88 log units), on the high side; measured number outside the range, below it.
By their numbers in this assay, from the lowest: compounds 4 and 3 (each within the scatter of the next); then compounds 2 and 1 (each within the scatter of the next).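

In this assay, the aryl on the amide-type nitrogen is shown to respond beyond the scatter: trifluoromethyl in place of hydrogen on an aromatic carbon, meta to a trifluoromethyl group, gives a 9.3-fold lower number from compound 1 to compound 4 (0.97 log units; beyond the scatter), whereas the only earlier change on this aryl gave a 2.0-fold lower number from compound 1 to compound 2 (0.30 log units; within the scatter). No measurement bears on the reason for the step.

From the compounds shown here alone, whether a nitrile or an amine on the same aromatic carbon gives a comparable step stays open. Also open, going by these compounds, is whether the methyl on the oxygen in compound 3 adds to the trifluoromethyl gain in compound 4.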